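This account rests on a few compounds, and the source may have more. Where it says the series, first, only, none or still open, it means among the compounds named here.

Working notes on the series. In a physicochemical assay for solubility (on this read-out lower numbers stand for lower solubility and higher numbers for higher solubility), compound 1 `O=C(c1ccccc1)N1CCC(NS(=O)(=O)c2cc(S(=O)(=O)c3ccccc3)ccc2C(F)(F)F)CC1` gives 12500 nM and compound 2 `O=C(c1cccnc1)N1CCC(NS(=O)(=O)c2cc(S(=O)(=O)c3ccccc3)ccc2C(F)(F)F)CC1` gives 50000 nM, so compound 2 holds the higher of the two numbers. Compound 3 `O=C(O)c1ccc(S(=O)(=O)N2CCC(NS(=O)(=O)c3cc(S(=O)(=O)c4ccccc4)ccc3C(F)(F)F)CC2)cc1` has not yet been measured. It carries (4-carboxyphenyl)sulfonyl in place of (pyridin-3-yl)carbonyl on an amine nitrogen in a ring.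

Among the measured compounds shown here, only one measured step bears on this change, and only in part. That step, a 4.0-fold higher number from compound 1 to compound 2 (0.60 log units; beyond the scatter), is modest and concerns the ring on the carbonyl group, which now leaves altogether. For the measured compounds named here, the series holds no measured compound with a sulfonyl group at this ring nitrogen, and none with a carboxyphenyl group, so the data give no firm direction. In this assay, no step beyond the usual scatter is therefore expected, although the uncertainty is wide on both sides. The expected step is a 1.2-fold higher number from compound 2 to compound 3 (0.08 log units; within the scatter). For compound 3 the estimated value is 60000 nM, with an expected range from 15000 nM to 200000 nM.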

Compound 3, solubility: 12500 nM
Compound 3: middle estimate off by 4.8-fold (0.68 log units), on the high side; measured number outside the range, below it.
By their numbers in this assay, from the lowest: compounds 1 and 3 (each within the scatter of the next); then compound 2.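

At the amine nitrogen in the ring, this assay now responds to replacing the whole group, not only the ring on the carbonyl: (4-carboxyphenyl)sulfonyl in place of (pyridin-3-yl)carbonyl gives a 4.0-fold lower number from compound 2 to compound 3 (0.60 log units; beyond the scatter) and the same group in place of benzoyl gives no change at the digits printed from compound 1 to compound 3 (within the scatter) on this read-out. Compound 2 therefore remains the only one of the three with a higher number, and its steps to compound 1 and compound 3 are equal in size at the digits printed, while this read-out does not separate the benzoyl group of compound 1 from the (4-carboxyphenyl)sulfonyl group of compound 3. No measurement at hand accounts for either step.

The sulfonyl link and the carboxylic acid on the aromatic ring enter together in compound 3, so their separate contributions remain unresolved, as does whether the equal numbers of compound 1 and compound 3 hold for other groups at this nitrogen. A phenylsulfonyl, (pyridin-3-yl)sulfonyl or (4-carboxyphenyl)carbonyl group at the same nitrogen would each change only part of that pairing.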